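The source may hold more compounds than are shown below. What is called first, only, known or untested is meant among the compounds shown, and "the series" means these compounds.

Measured so far in a functional assay on liver (Sus scrofa) for inhibition of squalene monooxygenase (Homo sapiens), using microsomes; on this read-out higher numbers stand for weaker inhibition and lower numbers for stronger inhibition:
- compound 1 `CCN(CC#CC#CC(C)(C)OC)Cc1cccc(OC[Si](C)(C)c2ccccc2C)c1` — 70 nM
- compound 2 `CCN(C/C=C/C#CC(C)(C)C)Cc1cccc(OC[Si](C)(C)c2ccc(C)cc2)c1` — 120 nM
- compound 3 `CCN(C/C=C/C#CC(C)(C)C)Cc1cccc(OC[Si](C)(C)c2cccc(C)c2)c1` — 3000 nM

Compound 1 sits at the low end of these three numbers; compound 2 lies within the scatter of it, while compound 3 is far beyond. Within the data shown here, the one measured step on this assay, a 25-fold higher number from compound 2 to compound 3 (1.40 log units; beyond the scatter), concerns only the methylphenyl on silicon and is large.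

Compound 4 `CCN(C/C=C/C#CC(C)(C)C)Cc1cccc(OC[Si](C)(C)c2ccccc2C)c1` keeps the silicon aryl of compound 1 and changes the chain on the amine: a group of 8 heavy atoms (8 carbon; no ring) in place of a group of 9 heavy atoms (8 carbon, 1 oxygen; no ring), on a saturated chain carbon bound to an amine nitrogen. Among the measured compounds shown here, no measured pair differs only in this chain, so no step bears directly on it. The closest comparison is compound 2, which carries the entering chain with a different aryl and gives a number within the scatter of compound 1; that weak hint is all there is, and the aryl step warns that small changes elsewhere can move the number a lot.

The expectation for compound 4 is therefore a step of about a 1.4-fold higher number from compound 1 to compound 4 (0.15 log units; within the scatter) in this assay, not beyond the scatter, with an estimate of 100 nM and a range from 30 nM to 400 nM.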

Compound 4, half-maximal inhibitory concentration: 30 nM
For compound 4 the middle estimate is 3.3-fold (0.52 log units) above the measured one; low and high end bracket the measured number.
By their numbers in this assay, from the lowest: compound 4; then compounds 1 and 2 (each within the scatter of the next); then compound 3.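

In this assay the chain on the amine turns out to matter in its own right: a 2.3-fold lower number from compound 1 to compound 4 (0.37 log units; beyond the scatter) is a modest step, with the group of 8 heavy atoms (8 carbon; no ring) in place of the group of 9 heavy atoms (8 carbon, 1 oxygen; no ring), on a saturated chain carbon bound to an amine nitrogen. With that chain held constant, the methylphenyl on silicon can now be read across all three placements: a 100-fold lower number from compound 3 to compound 4 (2.00 log units; beyond the scatter) is a large step and a 4.0-fold lower number from compound 2 to compound 4 (0.60 log units; beyond the scatter) is a modest one. The 2-methylphenyl of compound 4 therefore gives the strongest inhibition of the set, ahead of the 4-methylphenyl and then the 3-methylphenyl.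

No data on hand explain these steps. Still open, as far as these compounds go, is whether this order holds with the chain of compound 1, and what a 2-chlorophenyl or an unsubstituted phenyl on the silicon would give.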